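The source may report more compounds than this note shows. Statements on the series, on what has been measured and on what is new or still open speak of the compounds shown alone.

In an ADME assay (liver) for metabolic stability, with Liver microsome (Homo sapiens) as the target, using microsomes and NADPH, with a stated time of 30 min, tested at 1 uM (a higher number here means faster removal of the compound, a lower number slower removal), three compounds with a shared core differ at one aromatic carbon. Compound 1 `Nc1ccc(S(=O)(=O)N2CCN(c3ncc(C(O)(C(F)(F)F)C(F)(F)F)cc3Br)CC2)cn1`, with bromo there, reports only a limit, < 14 mL.min-1.g-1. Compound 2 `Nc1ccc(S(=O)(=O)N2CCN(c3ncc(C(O)(C(F)(F)F)C(F)(F)F)cc3C#CCO)CC2)cn1`, with 3-hydroxyprop-1-yn-1-yl there, also reports only a limit, < 14 mL.min-1.g-1. Going by the values given here, compound 3 `Cn1cc(-c2cc(C(O)(C(F)(F)F)C(F)(F)F)cnc2N2CCN(S(=O)(=O)c3ccc(N)nc3)CC2)cn1`, with 1-methyl-1H-pyrazol-4-yl there, gives 19 mL.min-1.g-1, the only true number of the three.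

Compound 4 `Nc1ccc(S(=O)(=O)N2CCN(c3ncc(C(O)(C(F)(F)F)C(F)(F)F)cc3-c3cccc(F)c3)CC2)cn1` changes that same carbon: 3-fluorophenyl in place of 1-methyl-1H-pyrazol-4-yl on an aromatic carbon. It thus places 3-fluorophenyl on an aromatic carbon of a six-membered aromatic ring with 1 nitrogen, ortho to a large group.

The measured steps at this carbon give only weak guidance. Replacing bromo gave an at least 1.3-fold higher number from compound 1 to compound 3 (0.13 log units; that floor lies within the scatter), and replacing 3-hydroxyprop-1-yn-1-yl gave an at least 1.3-fold higher number from compound 2 to compound 3 (0.13 log units; that floor lies within the scatter). The remaining pair shows a step that the two limits leave unreadable from compound 1 to compound 2. None of these steps exchanges one aromatic ring for another, so no large change is expected. Compound 3, the only one of the three with a ring at this carbon, sits at 19 mL.min-1.g-1, and compound 4 also carries a ring there, so a number close to this one is expected. The expected change is small and slightly upward, a 1.3-fold higher number from compound 3 to compound 4 (0.10 log units; within the scatter), and is not expected to clear the scatter. For compound 4 the estimate is 24 mL.min-1.g-1, with an expected range from 12 mL.min-1.g-1 to 48 mL.min-1.g-1.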

Compound 4, intrinsic clearance in microsomes: 25 mL.min-1.g-1
Compound 4: middle estimate off by 1.0-fold (0.02 log units), on the low side; the measured number falls inside the stated range.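

In this assay, going by these compounds alone, the new result gives the first readable step between two aromatic rings at this carbon: a 1.3-fold higher number from compound 3 to compound 4 (0.12 log units; within the scatter). Thus 3-fluorophenyl, a six-membered aromatic ring of carbon only with 0 hydrogen-bond acceptors, and 1-methyl-1H-pyrazol-4-yl, a five-membered aromatic ring with 2 hydrogen-bond acceptors, cannot be told apart here. Set against the two groups without a ring, the result gives an at least 1.7-fold higher number from compound 1 to compound 4 (0.25 log units; that floor lies within the scatter) and an at least 1.7-fold higher number from compound 2 to compound 4 (0.25 log units; that floor lies within the scatter), and with both floors inside the scatter, neither step establishes a difference from compound 4, whose floors rest on a limit of the assay rather than on a number: the limit of < 14 mL.min-1.g-1 in this assay, at which 2 of the 4 values shown sit.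

The compounds shown leave open how a phenyl group without fluorine, an amine or a carboxylic acid at this carbon would read in this assay. As far as these compounds go, compound 1 and compound 2 each report only a limit, and their true numbers remain open.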